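An Isopropoxy Group Enters the Core of Compound 1

This account rests on a few compounds, and the source may have more. Where it says the series, first, only, none or still open, it means among the compounds named here.

Compound 1 `O=c1c(-c2nn[nH]n2)c[nH]c2ccccc12` was tested in a functional assay on the whole organism (strain Sprague-Dawley) for inhibition, with Rattus norvegicus as the target (on this read-out higher numbers stand for an effect only at larger amounts of compound and lower numbers for an effect already at smaller amounts), where compound 1 gives 1.25 mg/kg. Two measured relatives share its core. Compound 2 `Cc1ccc2[nH]cc(-c3nn[nH]n3)c(=O)c2c1` gives 1.25 mg/kg in this assay, and compound 3 `O=c1c(-c2nn[nH]n2)c[nH]c2ccc(F)cc12` gives 1.25 mg/kg. Compound 1 thus stands level with both at the digits shown, its nearest neighbour being compound 2 and its furthest compound 3, and neither gap reaches beyond the scatter. The measured steps say the same: no change at the digits printed from compound 1 to compound 2 (within the scatter), no change at the digits printed from compound 1 to compound 3 (within the scatter) and no change at the digits printed from compound 2 to compound 3 (within the scatter).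

Compound 4 `CC(C)Oc1cccc2c(=O)c(-c3nn[nH]n3)c[nH]c12` differs from compound 1 in one place: isopropoxy in place of hydrogen on an aromatic carbon. Within the data shown here, no measured step puts an isopropoxy group on the core, so the evidence is indirect. Among the measured compounds shown here, the steps that bear on it are those in which a hydrogen on an aromatic carbon gave way to methyl or to fluoro, each leaving the minimum effective dose unchanged within the scatter. On that basis the step of no change at the digits printed from compound 1 to compound 4 (within the scatter) is expected to be small, in no firm direction, with a widened range to reflect the untested group. Compound 4 is therefore estimated at 1.25 mg/kg, between 0.5 mg/kg and 5 mg/kg.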

Compound 4, minimum effective dose: 0.078 mg/kg
For compound 4 the middle estimate is 16-fold (1.20 log units) above the measured one; measured number outside the range, below it.
By their numbers in this assay, from the lowest: compound 4; then compounds 1, 2 and 3 (each within the scatter of the next).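

In this assay the core of compound 1 turns out to respond to a change on its six-membered aromatic ring of carbon only: with isopropoxy in place of hydrogen there is a 16-fold lower number from compound 1 to compound 4 (1.20 log units; beyond the scatter) and the effect appears at a much smaller dose. The earlier swaps gave no such sign, with no change at the digits printed from compound 1 to compound 2 (within the scatter) for methyl and no change at the digits printed from compound 1 to compound 3 (within the scatter) for fluoro, so compound 4 is the first compound shown to separate from the others on this read-out. No measurement shown gives a reason for this large step.

The compounds shown do not settle whether the step belongs to the isopropoxy group itself or to the carbon that carries it, ortho to a fused ring and meta to a fused ring, since the methyl of compound 2 and the fluoro of compound 3 stand on a different aromatic carbon of the shared core. Also open, from the compounds shown here alone, is what a methoxy group, a longer butoxy chain or an amine would do on the carbon that carries isopropoxy in compound 4, and whether methyl or fluoro there would leave the dose unchanged.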